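A few compounds are considered here, and "the series" means these few. Any claim that something is new, unique, unknown or untested is made for them only; others in the source may bear on it.

Compound 1 `CON(C)C(=O)C1(S(=O)(=O)c2ccc(Oc3ccc(OC(F)(F)F)cc3)cc2)CCC2(CCNCC2)C1` gives 3700 nM.
Compound 2 `O=S(=O)(c1ccc(Oc2ccc(OC(F)(F)F)cc2)cc1)C1(CO)CCC2(CCNCC2)C1` gives only a limit, > 15000 nM.
Compound 3 `O=C(Nc1nccs1)C1(S(=O)(=O)c2ccc(Oc3ccc(OC(F)(F)F)cc3)cc2)CCC2(CCNCC2)C1` gives only a limit, > 15000 nM.

Three compounds share one core and differ only in the group carried on a saturated ring carbon. Within the data shown here, in a functional assay on blood (Homo sapiens), with a stated time of 60 min, in the presence of a further agent that is not named here (a lower number here means that less compound is needed, a higher number that more compound is needed for the effect), compound 1 is the one compound with a number; the other two values are limits of the assay, not numbers. Both of them sit at the limit of > 15000 nM in this assay, at which 2 of the 3 values shown sit.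

Compound 4 `CN(C)S(=O)(=O)NC(=O)C1(S(=O)(=O)c2ccc(Oc3ccc(OC(F)(F)F)cc3)cc2)CCC2(CCNCC2)C1` is not yet measured. It differs from compound 1 in one place: (dimethylsulfamoyl)amino in place of methoxy(methyl)amino on a carbonyl carbon. Two measured steps start from compound 1 and alter the same region: an at least 4.0-fold higher number from compound 1 to compound 2 (0.60 log units; beyond the scatter) and an at least 4.0-fold higher number from compound 1 to compound 3 (0.60 log units; beyond the scatter). Each of these changes raised the number beyond the scatter, and neither gave a number to compare against, only a limit. The change to compound 4 is once more a change at the carbonyl carbon, so a higher number is expected for compound 4, by a 3.2-fold higher number from compound 1 to compound 4 (0.51 log units; beyond the scatter). For compound 4 the expected value is 12000 nM, with a range from 3000 nM to 40000 nM, and a limit instead of a number is a real possibility.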

Compound 4, half-maximal effective concentration: > 15000 nM
Compound 4: a limit, no number (the forecaster's own chance of this, stated with the estimate: 50%); middle value at least 1.2-fold (0.09 log units) away from the limit.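

In this assay, (dimethylsulfamoyl)amino on the carbonyl carbon gives an at least 4.0-fold higher number from compound 1 to compound 4 (0.60 log units; beyond the scatter), so this is a second replacement at that carbon that raises the number beyond the scatter. With compound 3, which carries (1,3-thiazol-2-yl)amino there, the loss is now seen with two different groups, one with a ring and one without, so the thiazole ring is not needed for it. Compound 1 remains the only one of the four compounds with a number, and the value of compound 4 is a limit, not a number: the limit of > 15000 nM in this assay, at which 3 of the 4 values shown sit.

The steps among compound 2, compound 3 and compound 4 cannot be read, as each joins two limits. Going by these compounds, whether methoxy, dimethylamino or hydroxy on the carbonyl carbon would give a number, and how it would compare with compound 1, stays open.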